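This account rests on a few compounds, and the source may have more. Where it says the series, first, only, none or still open, it means among the compounds named here.

Compound 2 `NCCCCCOC[C@H]1O[C@@H](OCCc2c[nH]c3ccccc23)[C@H](OCc2ccccc2)[C@@H](OCc2ccccc2)[C@@H]1OCc1cnccn1` gives 260 nM in an assay on isolated protein for binding affinity to somatostatin receptor type 4 (Homo sapiens), read by radioligand binding (on this read-out lower numbers stand for stronger inhibition and higher numbers for weaker inhibition), the lower of the two numbers measured; compound 1 `NCCCCCOC[C@H]1O[C@@H](OCCc2c[nH]c3ccccc23)[C@H](OCc2ccccc2)[C@@H](OCc2ccccc2)[C@@H]1OCc1ccncc1` gives 570 nM in this assay, and the step of a 2.2-fold lower number from compound 1 to compound 2 (0.34 log units; beyond the scatter) came from swapping one six-membered aromatic ring for another on the same saturated chain carbon. Compound 3 `NCCCCCOC[C@H]1O[C@@H](OCCc2c[nH]c3ccccc23)[C@H](OCc2ccccc2)[C@@H](OCc2ccccc2)[C@@H]1OCc1ccc(Cl)nc1` differs from compound 2 by 6-chloropyridin-3-yl in place of pyrazin-2-yl on a saturated chain carbon bound to an oxygen on a saturated carbon, again a swap of that ring. For the measured compounds named here, only the step from compound 1 to compound 2 bears on this change, and it was modest, so the expected step of a 1.2-fold higher number from compound 2 to compound 3 (0.06 log units; within the scatter) is small and could fall either way. Compound 3 is therefore estimated at 300 nM, within 120 nM to 800 nM.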

Compound 3, inhibition constant: 1200 nM
Compound 3: the middle estimate sits 4.0-fold (0.60 log units) below what was measured; measured number above the stated range.
By their numbers in this assay, from the lowest: compound 2; then compound 1; then compound 3.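

In this assay, the ring at this place clearly affects the number, and 6-chloropyridin-3-yl gives the weakest binding of the three rings, with a 4.6-fold higher number from compound 2 to compound 3 (0.66 log units; beyond the scatter) and a 2.1-fold higher number from compound 1 to compound 3 (0.32 log units; beyond the scatter). The ring swap also adds a chlorine, which neither earlier ring carries, so these steps cannot separate the effect of the chlorine from that of the ring itself. No measurement here explains the loss in binding. Open, going by these compounds, is how much of the step belongs to the chlorine; plain pyridin-3-yl, without a chlorine, would help to answer that.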